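A Trimethoxyphenyl Analogue of Compound 2

This account rests on a few compounds, and the source may have more. Where it says the series, first, only, none or still open, it means among the compounds named here.

In a functional assay on MCF7 cells (Homo sapiens) for inhibition, read by MTT assay, with a stated time of 72 h (on this read-out higher numbers stand for weaker inhibition and lower numbers for stronger inhibition), compound 2 `CC(C)c1ccc(-c2nc(SCc3cn(CC(=O)NC(=O)Nc4ccccn4)nn3)nc(Nc3cccc(C(F)(F)F)c3)c2C#N)cc1` gives 8620 nM, the lowest of the two numbers measured. Compound 1 `CC(C)c1ccc(-c2nc(SCc3cn(CC(=O)NC(=O)Nc4ccccn4)nn3)nc(Nc3cccc(Cl)c3)c2C#N)cc1` gives 18000 nM in this assay, and the step of a 2.1-fold lower number from compound 1 to compound 2 (0.32 log units; beyond the scatter) separates the two. Compound 3 `Cc1cccc(Nc2nc(SCc3cn(CC(=O)NC(=O)Nc4ccccn4)nn3)nc(-c3ccc(C(C)C)cc3)c2C#N)c1` yields only a limit of > 64000 nM in this assay. The steps of an at least 3.5-fold higher number from compound 1 to compound 3 (0.55 log units; beyond the scatter) and an at least 7.4-fold higher number from compound 2 to compound 3 (0.87 log units; beyond the scatter) follow from that limit (the limit of > 64000 nM in this assay, at which 1 of the 3 values shown sits).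

Compound 4 `COc1cc(-c2nc(SCc3cn(CC(=O)NC(=O)Nc4ccccn4)nn3)nc(Nc3cccc(C(F)(F)F)c3)c2C#N)cc(OC)c1OC` differs from compound 2 by 3,4,5-trimethoxyphenyl in place of 4-isopropylphenyl on an aromatic carbon. Going by the values given here, none of the measured steps alters this part of the core; each changes only the substituent on the anilino ring, so no measured step bears directly on the change. Compound 4 is therefore expected near compound 2, with a step of a 1.4-fold lower number from compound 2 to compound 4 (0.16 log units; within the scatter). The estimate for compound 4 is 6000 nM, ranging from 1500 nM to 25000 nM.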

Compound 4, half-maximal inhibitory concentration: 8140 nM
The estimate for compound 4 lay 1.4-fold (0.13 log units) below the measured number; low and high end bracket the measured number.
By their numbers in this assay, from the lowest: compounds 4 and 2 (each within the scatter of the next); then compound 1. At a limit, above all of these: compound 3.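

Among the compounds shown, this position changes here for the first time: with 3,4,5-trimethoxyphenyl in place of 4-isopropylphenyl, this assay gives a 1.1-fold lower number from compound 2 to compound 4 (0.02 log units; within the scatter). This exchange therefore leaves the read-out within the scatter, whereas each earlier exchange, among chloro, trifluoromethyl and methyl, gave a step beyond it. Nothing measured here explains this result.

As far as these compounds go, whether an amine or a carboxylic acid on this aromatic ring would move the number remains open. So does whether the same exchange would behave alike with chloro or methyl in place of trifluoromethyl.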